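The source may hold more compounds than are shown below. What is called first, only, known or untested is meant among the compounds shown, and "the series" means these compounds.

In a functional assay on OVCAR-3 cells (Homo sapiens) for antiproliferative activity, read by MTT assay, with a stated time of 24 h (a lower number here means a stronger inhibitor, a higher number a weaker inhibitor), compound 1 (`Cc1ccccc1NNC(=O)c1ccc(NS(=O)(=O)c2cnc(O)nc2O)cc1`) gives > 20000 nM, which is a limit. Compound 2 (`Cc1cccc(NNC(=O)c2ccc(NS(=O)(=O)c3cnc(O)nc3O)cc2)c1`) gives > 20000 nM, which is also a limit. Compound 3 (`O=C(NNc1ccccc1Cl)c1ccc(NS(=O)(=O)c2cnc(O)nc2O)cc1`) carries 2-chlorophenyl in place of 3-methylphenyl on an amine nitrogen, relative to compound 2 (2-chlorophenyl in place of 3-methylphenyl on an amine nitrogen). Among the measured compounds shown here, the only measured step bearing on this is a step that the two limits leave unreadable from compound 1 to compound 2, and what the series offers is the limit of > 20000 nM in this assay, at which 2 of the 2 values shown sit. No step beyond the scatter, and no direction, is therefore expected in this assay. The expected step is a step that the limit leaves unreadable from compound 2 to compound 3. For compound 3 the estimate is 30000 nM, within an expected range of 10000 nM to 80000 nM.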

Compound 3, half-maximal inhibitory concentration: 7230 nM
Compound 3: middle estimate off by 4.1-fold (0.62 log units), on the high side, outside the stated range (below it).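

In this assay, 2-chlorophenyl in place of 3-methylphenyl on an amine nitrogen gives an at least 2.7-fold lower number from compound 2 to compound 3 (0.44 log units; beyond the scatter), and chloro in place of methyl on an aromatic carbon gives an at least 2.7-fold lower number from compound 1 to compound 3 (0.44 log units; beyond the scatter). This place therefore does respond to the change, and both steps give only a lower bound on the true size. The step between compound 1 and compound 2 cannot be read, and the values of both compounds are limits: the limit of > 20000 nM in this assay, at which 2 of the 3 values shown sit.

As far as these compounds go, whether bromo, trifluoromethyl or methoxy in place of chloro would also give a readable value stays open.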